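Compound 3 to compound 4: a piperidine amide exchange

The compounds below may be only part of what the source reports. "The series", "measured", "known", "first", "only" and "open" are said of these compounds alone.

In a functional assay on A549 cells (Homo sapiens) for antiproliferative activity, read by sulforhodamine B assay, with a stated time of 3 days (on this read-out higher numbers stand for weaker inhibition of growth and lower numbers for stronger inhibition of growth), compound 1 (`O=C(Nc1nccs1)c1cccc(Nc2ncc(F)c(Nc3ccc(F)cc3)n2)c1`) gives > 10000 nM as a limit of the assay and not a number. Compound 2 (`COc1ccc(NC(=O)c2cccc(Nc3ncc(F)c(Nc4ccc(F)cc4)n3)c2)cc1`) gives 11000 nM in this series. Compound 3 (`O=C(Nc1cccc(Nc2ncc(F)c(Nc3ccc(F)cc3)n2)c1)c1cnccn1`) gives 10300 nM on the same read-out and stands level with compound 2 within the scatter. Among the measured compounds shown here, the only step of readable size is a 1.1-fold lower number from compound 2 to compound 3 (0.03 log units; within the scatter) for ((pyrazin-2-yl)carbonyl)amino in place of (4-methoxyphenyl)carbamoyl on an aromatic carbon. The steps a step that the limit leaves unreadable from compound 1 to compound 2 and a step that the limit leaves unreadable from compound 1 to compound 3 offer no size, and both rest on the limit of > 10000 nM in this assay, at which 1 of the 3 values shown sits, alone.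

Compound 4 (`O=C(c1cccc(Nc2ncc(F)c(Nc3ccc(F)cc3)n2)c1)N1CCCCC1`) carries (piperidin-1-yl)carbonyl in place of ((pyrazin-2-yl)carbonyl)amino on the same aromatic carbon ((piperidin-1-yl)carbonyl in place of ((pyrazin-2-yl)carbonyl)amino on an aromatic carbon) of the shared core. For the measured compounds named here, the one sized exchange at this place stayed within the scatter, so starting from compound 3 at 10300 nM no step beyond the scatter is expected. From the compounds shown here alone, the expected step is a 1.1-fold higher number from compound 3 to compound 4 (0.03 log units; within the scatter) in this assay and its direction stays open. A report as a limit, as with compound 1, remains a real possibility. In this assay the estimate for compound 4 is 11000 nM with an expected range from 6000 nM to 20000 nM around it.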

Compound 4, concentration for 50% growth inhibition: 13200 nM
Estimate against measurement, compound 4: 1.2-fold (0.08 log units) below, and the stated range covers the measured number.
By their numbers in this assay, from the lowest: compounds 3, 2 and 4 (each within the scatter of the next).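

On the aromatic carbon meta to a large group, the exchange in this assay gives a 1.3-fold higher number from compound 3 to compound 4 (0.11 log units; within the scatter), with a six-membered non-aromatic ring and 0 hydrogen-bond donors entering for a six-membered aromatic ring and 1 hydrogen-bond donor. Read on the carbonyl carbon, piperidin-1-yl in place of (4-methoxyphenyl)amino gives a 1.2-fold higher number from compound 2 to compound 4 (0.08 log units; within the scatter), so compound 4, the first compound here with neither an amide hydrogen nor a second aromatic ring in this group, stands level with compound 2 and compound 3. Compound 1 is reported only as a limit of the assay and not a number, and the steps from it cannot be read: the limit of > 10000 nM in this assay, at which 1 of the 4 values shown sits.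

From the compounds shown here alone, compound 2, compound 3 and compound 4 stand within the scatter of one another, so it stays open whether any group on this aromatic carbon can shift the number beyond the scatter. An amine such as 4-methylpiperazin-1-yl, a carboxylic acid or a longer chain carrying either group would extend the comparison at this place.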